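A few compounds are considered here, and "the series" means these few. Any claim that something is new, unique, unknown or untested is made for them only; others in the source may bear on it.

Among the measured compounds shown here, in a functional assay on COLO 205 cells (Homo sapiens) for inhibition, read by sulforhodamine B assay, with a stated time of 48 h (on this read-out higher numbers stand for weaker inhibition of growth and lower numbers for stronger inhibition of growth), compound 2 `Nc1cc(N)c2nc(-c3ccccc3)c(NCc3ccc(Cl)c(Cl)c3)nc2c1` gives 33900 nM, the only actual number among the three measured compounds. Compound 1 `CCOC(=O)[C@H](CCC(=O)O)NC(=O)c1ccc(CNc2nc3cc(N)cc(N)c3nc2-c2ccccc2)cc1` gives only a limit in this assay, < 100000 nM. Compound 3 `CCOC(=O)[C@H](CCC(=O)O)NC(=O)c1ccc(Oc2nc3cc(N)cc(N)c3nc2-c2ccccc2)cc1` likewise gives only a limit, < 100000 nM. Two of the three results therefore sit at the limit of < 100000 nM in this assay, at which 2 of the 3 values shown sit, so compound 2 alone anchors the comparison.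

Compound 4 `COc1ccc(CNc2nc3cc(N)cc(N)c3nc2-c2ccccc2)cc1` differs from compound 2 by 4-methoxyphenyl in place of 3,4-dichlorophenyl on a saturated chain carbon bound to a nitrogen on an aromatic ring, that is, 4-methoxybenzyl in place of 3,4-dichlorobenzyl. For the measured compounds named here, no measured pair shows this change, so the expected step rests on compound 2 alone. A modest move toward weaker growth inhibition is expected, a 2.1-fold higher number from compound 2 to compound 4 (0.31 log units; beyond the scatter), beyond the usual scatter but not far. Compound 4 is thus estimated at 70000 nM, with a range from 25000 nM to 150000 nM.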

Compound 4, concentration for total growth inhibition: 33900 nM
For compound 4 the middle estimate is 2.1-fold (0.31 log units) above the measured one; the measured number falls inside the stated range.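

On a saturated chain carbon bound to a nitrogen on an aromatic ring, 4-methoxyphenyl in place of 3,4-dichlorophenyl gives no change at the digits printed from compound 2 to compound 4 (within the scatter) in this assay. Among the compounds shown here, this is the first pair of actual numbers at this position, and the read-out does not separate these two rings, although one carries chlorine and the other a methoxy oxygen. Nothing measured here gives a reason for this match.

From the compounds shown here alone, whether an amine or a carboxylic acid on this ring would read the same remains open. So does the effect of a longer chain on that nitrogen.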